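The source may report more compounds than this note shows. Statements on the series, on what has been measured and on what is new or still open speak of the compounds shown alone.

Two acids in the series have been measured in an assay on HEK-293T cells for antagonist activity at vitamin D3 receptor (Homo sapiens), read by a luciferase reporter, with a stated time of 24 h; on this read-out higher numbers stand for weaker inhibition and lower numbers for stronger inhibition. Compound 1 `CC(C)c1onc(-c2c(Cl)cccc2Cl)c1COc1ccc(-c2nc3ccc(C(=O)O)cc3n2-c2ccc(F)cc2)cc1` gives 2410 nM. Compound 2 `CC(C)c1onc(-c2c(Cl)cccc2Cl)c1COc1ccc(-c2nc3ccc(C(=O)O)cc3n2C)cc1Cl` gives 2450 nM; the two values lie within the usual scatter of each other, so neither compound can be ranked ahead of the other on these numbers. As far as these compounds go, compound 3 `CC(C)c1onc(-c2c(Cl)cccc2Cl)c1COc1ccc(-c2nc3ccc(C(=O)O)cc3n2C)cc1` is untested; it differs from compound 2 by hydrogen in place of chloro on an aromatic carbon. Going by the values given here, no measured pair isolates this change, so no step beyond the scatter is expected in this assay, and the estimated step of a 1.0-fold lower number from compound 2 to compound 3 (0.01 log units; within the scatter) stays near zero. Compound 3 is expected to give about 2400 nM, ranging from 1000 nM to 6000 nM.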

Compound 3, half-maximal inhibitory concentration: 7150 nM
Compound 3: middle estimate off by 3.0-fold (0.47 log units), on the low side; the whole stated range lies below it.
By their numbers in this assay, from the lowest: compounds 1 and 2 (each within the scatter of the next); then compound 3.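

In this assay the chloro on this aromatic carbon counts: hydrogen in its place gives a 2.9-fold higher number from compound 2 to compound 3 (0.47 log units; beyond the scatter) and so loses inhibition. The aromatic nitrogen also responds, since methyl in place of 4-fluorophenyl gives a 3.0-fold higher number from compound 1 to compound 3 (0.47 log units; beyond the scatter) and a similar loss. No measurement here explains either step.
Still open, as far as these compounds go, is how fluoro or methoxy would read on that aromatic carbon, and how a benzyl group or a longer chain would read on the aromatic nitrogen. Also open, from the compounds shown here alone, is whether chloro and 4-fluorophenyl together would go further than either alone.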